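Swapping the Aryl Group for Pyridin-2-yl

The source may report more compounds than this note shows. Statements on the series, on what has been measured and on what is new or still open speak of the compounds shown alone.

Measured in an ADME assay on HEK293 cells for displacement of a labelled ligand from 5-hydroxytryptamine receptor 7 (Homo sapiens), read by radioligand binding, with a stated time of 1 h; on this read-out lower numbers stand for stronger inhibition and higher numbers for weaker inhibition:
compound 1 `O=C1c2ccccc2S(=O)(=O)N1CCCCCCN1CCN(c2ccccc2F)CC1` gives 322 nM
compound 2 `O=C1c2ccccc2S(=O)(=O)N1CCCCCCN1CCN(c2ccccc2C(F)(F)F)CC1` gives 195 nM
compound 3 `O=C1c2ccccc2S(=O)(=O)N1CCCCCCN1CCN(c2cccc(C(F)(F)F)c2)CC1` gives 58 nM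

Compound 3 gives the lowest of the three numbers in this assay; the step of a 3.4-fold lower number from compound 2 to compound 3 (0.53 log units; beyond the scatter) and the step of a 5.6-fold lower number from compound 1 to compound 3 (0.74 log units; beyond the scatter) both lie beyond the scatter, so compound 3 is the strongest of the measured three. Compound 4 `O=C1c2ccccc2S(=O)(=O)N1CCCCCCN1CCN(c2ccccn2)CC1` has not been measured. It differs from compound 3 in one place: pyridin-2-yl in place of 3-(trifluoromethyl)phenyl on an amine nitrogen in a ring. Within the data shown here, no measured step exchanges this aryl group for a ring that carries a nitrogen; the steps of a 1.7-fold lower number from compound 1 to compound 2 (0.22 log units; within the scatter), a 5.6-fold lower number from compound 1 to compound 3 (0.74 log units; beyond the scatter) and a 3.4-fold lower number from compound 2 to compound 3 (0.53 log units; beyond the scatter) only show that changing the group on the ring nitrogen shifts the number by a modest amount at most. Because compound 3 gives 58 nM with the 3-(trifluoromethyl)phenyl group in place, removing that group is expected to raise the number. The estimate for compound 4 is 250 nM, between 80 nM and 800 nM. The expected step is a 4.3-fold higher number from compound 3 to compound 4 (0.63 log units; beyond the scatter).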

Compound 4, inhibition constant: 552 nM
For compound 4 the middle estimate is 2.2-fold (0.34 log units) below the measured one; the range from low to high includes it.
By their numbers in this assay, from the lowest: compound 3; then compounds 2, 1 and 4 (each within the scatter of the next, the first and the last beyond it).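

In this assay, among these compounds, a ring that carries a nitrogen now sits on the amine nitrogen for the first time, and pyridin-2-yl gives a clearly weaker result than 3-(trifluoromethyl)phenyl (a 9.5-fold higher number from compound 3 to compound 4 (0.98 log units; beyond the scatter)) and than 2-(trifluoromethyl)phenyl (a 2.8-fold higher number from compound 2 to compound 4 (0.45 log units; beyond the scatter)). Against 2-fluorophenyl, the same swap cannot be told apart from repeat-measurement noise (a 1.7-fold higher number from compound 1 to compound 4 (0.23 log units; within the scatter)), so the choice of aryl group matters strongly only in some comparisons. Nothing available explains these differences.

The swap to compound 4 removes the trifluoromethyl group and adds the ring nitrogen in a single step, so the compounds shown leave open which of the two changes accounts for the higher number. A plain phenyl group, or a pyridin-2-yl ring carrying a trifluoromethyl group, would pull these two changes apart.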